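Fluoro in place of hydrogen on compound 2

The compounds below may be only part of what the source reports. "The series", "measured", "known", "first", "only" and "open" are said of these compounds alone.

In a functional assay on HeLa cells (Homo sapiens) for inhibition (on this read-out higher numbers stand for weaker inhibition and lower numbers for stronger inhibition), compound 1 `Cc1cn(/C=C/C=O)c(=O)[nH]c1=O` gives 1 uM and compound 2 `O=C/C=C/n1ccc(=O)[nH]c1=O` gives 4 uM as the higher of the two numbers. Compound 3 `O=C/C=C/n1cc(F)c(=O)[nH]c1=O` differs from compound 2 by fluoro in place of hydrogen on an aromatic carbon with fluoro in place of hydrogen on an aromatic carbon. Among the measured compounds shown here, the only measured step bearing on this change is a 4.0-fold higher number from compound 1 to compound 2 (0.60 log units; beyond the scatter) for hydrogen in place of methyl on an aromatic carbon. For the measured compounds named here, no fluoro compound has been measured, so only a smaller move toward lower numbers is expected. The expected size is a 2.0-fold lower number from compound 2 to compound 3 (0.30 log units; within the scatter) as estimated here. Compound 3 is estimated at 2 uM with a range from 0.6 uM to 6 uM expected.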

Compound 3, concentration for 50% inhibition: 3 uM
For compound 3 the middle estimate is 1.5-fold (0.18 log units) below the measured one, within the range that was stated.
By their numbers in this assay, from the lowest: compound 1; then compounds 3 and 2 (each within the scatter of the next).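

In this assay fluoro and hydrogen on this aromatic carbon are not separated, with a 1.3-fold lower number from compound 2 to compound 3 (0.12 log units; within the scatter) as the step between them. Methyl stands apart from fluoro as it does from hydrogen, with a 3.0-fold higher number from compound 1 to compound 3 (0.48 log units; beyond the scatter) on that replacement, so among these three groups only methyl separates beyond the scatter. No data on hand account for this reading.

Open, on these data alone, is whether ethyl, chloro or an amine on this carbon would read with methyl or with hydrogen and fluoro. As far as these compounds go, the 2-formylethenyl group stays constant across all three compounds, so its share in the read-out is also open.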